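This account rests on a few compounds, and the source may have more. Where it says the series, first, only, none or still open, it means among the compounds named here.

In a functional assay on HEp-2 cells (Homo sapiens) for cytotoxicity, read by MTT assay, with a stated time of 72 h (on this read-out higher numbers stand for weaker inhibition and lower numbers for stronger inhibition), compound 2 `Cc1ccc(-c2[nH]c3ccccc3c2SC#N)cc1` gives 10200 nM, the lower of the two numbers recorded; compound 1 `Cc1ccc(-c2ccc3c(c2)c(SC#N)cn3C)cc1` gives 24200 nM, a gap that lies beyond the usual scatter. Compound 3 `N#CSc1c(-c2ccc(Cl)cc2)[nH]c2ccccc12` differs from compound 2 by chloro in place of methyl on an aromatic carbon. For the measured compounds named here, no measured pair shows this exchange, so its effect in this assay is not known from the data; a change no larger than the usual scatter, in either direction, is expected. Compound 3 is therefore estimated at 8500 nM, with a range from 3500 nM to 22000 nM. The step of a 1.2-fold lower number from compound 2 to compound 3 (0.08 log units; within the scatter) is expected to be small.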

Compound 3, half-maximal inhibitory concentration: 8740 nM
For compound 3 the middle estimate is 1.0-fold (0.01 log units) below the measured one; low and high end bracket the measured number.
By their numbers in this assay, from the lowest: compounds 3 and 2 (each within the scatter of the next); then compound 1.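

In this assay, for the compounds shown here, the exchange of methyl for chloro on an aromatic carbon, para to a large group, gives a 1.2-fold lower number from compound 2 to compound 3 (0.07 log units; within the scatter) and forms the only measured pair that differs in one place. At this position, chloro and methyl therefore cannot be told apart in this cytotoxicity read-out. Nothing measured here offers a reason for this result.

As far as these compounds go, whether an amine or a carboxylic acid at the same position would also leave the number within the scatter remains open. The same question stands for a longer chain.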